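A few compounds are considered here, and "the series" means these few. Any claim that something is new, unique, unknown or untested is made for them only; others in the source may bear on it.

Compound 1 `CN1CCN(c2ccc(Nc3ncc4nc(Nc5cccc(Cl)c5)n(C5CCCC5)c4n3)cc2)CC1`: 390 nM
Compound 2 `CN1CCN(c2ccc(Nc3ncc4nc(Nc5ccc(Br)cc5)n(C5CCCC5)c4n3)cc2)CC1`: 2090 nM

In a functional assay on NCI-H1975 cells (Homo sapiens) for cytotoxicity, read by MTT assay, with a stated time of 72 h (a lower number here means a stronger inhibitor, a higher number a weaker inhibitor), compound 2 has the higher of the two numbers. Compound 3 `CN1CCN(c2ccc(Nc3ncc4nc(Nc5ccc(Br)cc5F)n(C5CCCC5)c4n3)cc2)CC1` differs from it as follows: fluoro in place of hydrogen on an aromatic carbon. This places fluoro in place of hydrogen on an aromatic carbon. Among the measured compounds shown here, the only measured step, a 5.4-fold higher number from compound 1 to compound 2 (0.73 log units; beyond the scatter), changed the same aromatic ring, but it did not add fluoro, so it gives no direct size or direction. No expected change beyond the scatter follows from it. The expected step is a 1.2-fold lower number from compound 2 to compound 3 (0.06 log units; within the scatter). For compound 3 the estimated value is 1800 nM, with an expected range of 600 nM to 5000 nM.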

Compound 3, half-maximal inhibitory concentration: 1120 nM
Beside the measured number, compound 3's estimate is 1.6-fold (0.21 log units) above it, and the stated range covers the measured number.
By their numbers in this assay, from the lowest: compound 1; then compounds 3 and 2 (each within the scatter of the next).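

Fluoro in place of hydrogen ortho to a large group gives a 1.9-fold lower number from compound 2 to compound 3 (0.27 log units; within the scatter) in this assay and so shows that this place on the 4-bromophenyl group takes fluoro with no change that stands clear of the scatter. With a 2.9-fold higher number from compound 1 to compound 3 (0.46 log units; beyond the scatter) as its step, the 4-bromo-2-fluorophenyl group still stands apart from 3-chlorophenyl, and compound 1 keeps the lowest number. No measurement at hand bears on the reason for either step. The compounds shown leave open whether a methoxy group or an amine at this place would match fluoro, and whether fluoro would do the same on the 3-chlorophenyl group.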